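A few compounds are considered here, and "the series" means these few. Any claim that something is new, unique, unknown or untested is made for them only; others in the source may bear on it.

Working notes on a small series built around the shared core of compound 1 `CCN(CC)C(=S)SCC1=CC(=O)OC1`. In a functional assay on PC-3 cells (Homo sapiens) for antiproliferative activity, read by MTT assay, with a stated time of 72 h (on this read-out higher numbers stand for weaker inhibition and lower numbers for stronger inhibition), compound 1 gives > 50 ug/mL, which is a limit of the assay rather than a number. Compound 2 `O=C1OCC=C1CSC(=S)NC1CCCCC1` likewise returns > 50 ug/mL in this assay, again a limit. Compound 3 `O=C1CC2(CO1)CSC(=S)N2c1ccc(Cl)cc1` also sits at a limit, with > 50 ug/mL in this assay. So the limit of > 50 ug/mL in this assay, at which 3 of the 3 values shown sit, is the whole of the record: no measured compound yields a number, and compound 1 stands exactly where every other member stands, with no ranking possible among them.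

Compound 4 `O=C1C=C(CSC(=S)N2CCCC2)CO1` has not yet been measured. It differs from compound 1 by pyrrolidin-1-yl in place of diethylamino on a thiocarbonyl carbon. Among the compounds with values here, no step between measured compounds exists, so any expectation for the size of the change in this assay rests only on the limit shared by all three. The step that the limit leaves unreadable from compound 1 to compound 4 is expected to be none beyond the usual scatter. Compound 4 is expected to give about 60 ug/mL, within 30 ug/mL to 150 ug/mL, and most probably to be reported once more as a limit rather than a number.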

Compound 4, half-maximal inhibitory concentration: > 50 ug/mL
Compound 4 gave a limit, no number; the forecaster's own chance of this, stated with the estimate: 85%; the middle value does not contradict the limit.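

Within the data shown here, compound 1 and compound 4 both end at a limit, so no step between them can be read in this assay: the limit of > 50 ug/mL in this assay, at which 4 of the 4 values shown sit. Still open, on these data alone, is how pyrrolidin-1-yl compares with diethylamino on a thiocarbonyl carbon, and whether any change to the shared core yields a number in this assay.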